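Swapping the indole for a hydroxynaphthalene

This account rests on a few compounds, and the source may have more. Where it says the series, first, only, none or still open, it means among the compounds named here.

Compound 1 `CN(C)CCn1cnnc1-c1cc(Oc2ccc(NC(=O)N/N=C/c3c[nH]c4ccccc34)cc2F)ccn1` has the lower of the two measured numbers in a functional assay on HT-29 cells (Homo sapiens) for cytotoxicity, read by MTT assay, with a stated time of 72 h (on this read-out lower numbers stand for stronger inhibition and higher numbers for weaker inhibition), where compound 1 gives 1300 nM. Within the data shown here, its only measured neighbour, compound 2 `COc1cc(/C=N/NC(=O)Nc2ccc(Oc3ccnc(-c4nncn4CCN(C)C)c3)c(F)c2)cc(OC)c1OC`, gives 3620 nM in this assay, and the step of a 2.8-fold higher number from compound 1 to compound 2 (0.44 log units; beyond the scatter) describes that single change. Compound 3 `CN(C)CCn1cnnc1-c1cc(Oc2ccc(NC(=O)N/N=C/c3c(O)ccc4ccccc34)cc2F)ccn1` is not yet measured. It differs from compound 1 in one place: 2-hydroxynaphthalen-1-yl in place of 1H-indol-3-yl on a carbon with a double bond to nitrogen. Among the measured compounds shown here, only one measured step speaks to this change, a 2.8-fold higher number from compound 1 to compound 2 (0.44 log units; beyond the scatter), which also replaced the 1H-indol-3-yl with another aromatic group and weakened inhibition modestly. Because a 2.8-fold higher number from compound 1 to compound 2 (0.44 log units; beyond the scatter) points that way, compound 3, in which 2-hydroxynaphthalen-1-yl takes the same place, is expected to show a modest weakening as well, though the two replacements are not alike, so the range is wide. Compound 3 is therefore estimated at 2200 nM, between 800 nM and 6000 nM, an expected step of a 1.7-fold higher number from compound 1 to compound 3 (0.23 log units; within the scatter).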

Compound 3, half-maximal inhibitory concentration: 670 nM
Compound 3: the middle estimate sits 3.3-fold (0.52 log units) above what was measured, and the stated range ends above it.
By their numbers in this assay, from the lowest: compounds 3 and 1 (each within the scatter of the next); then compound 2.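

In this assay, the step of a 1.9-fold lower number from compound 1 to compound 3 (0.29 log units; within the scatter) shows that this position accepts 2-hydroxynaphthalen-1-yl as well as 1H-indol-3-yl, so the loss seen with 3,4,5-trimethoxyphenyl does not follow from every replacement of the indole. The step of a 5.4-fold lower number from compound 2 to compound 3 (0.73 log units; beyond the scatter) confirms that the group on this carbon can shift the number by more than the usual scatter, with 2-hydroxynaphthalen-1-yl clearly ahead of 3,4,5-trimethoxyphenyl. No supporting evidence is available to explain why these groups behave differently.

Among these compounds, the role of the hydroxyl group in compound 3 remains open, as no compound here carries a plain naphthalen-1-yl group or an amino group in its place. It is also unknown whether a small group, such as a simple methyl on this carbon, would hold up as well as these larger aromatic groups.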